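Amine swap on a benzophenone amide, carried to a new core

A few compounds are considered here, and "the series" means these few. Any claim that something is new, unique, unknown or untested is made for them only; others in the source may bear on it.

Compound 1 `CCNCC(=O)Nc1cc(OC)ccc1C(=O)c1ccc(OC)c2c1OC(C)(C)C=C2` and compound 2 `COc1ccc(C(=O)c2ccc(OC)c3c2OC(C)(C)C=C3)c(NC(=O)CN(C)C)c1` share one core and differ only in the amide side chain. In a functional assay on HCT-8 cells (Homo sapiens) for antiproliferative activity, read by MTT assay, with a stated time of 48 h (a lower number here means a stronger inhibitor, a higher number a weaker inhibitor), compound 1 gives 3690 nM, while compound 2 gives 1590 nM. The change between them, (dimethylamino in place of ethylamino on a saturated chain carbon bound to a carbonyl carbon), produced a step of a 2.3-fold lower number from compound 1 to compound 2 (0.37 log units; beyond the scatter).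

Compound 3 `C=C(c1cc(OC)c(OC)c(OC)c1)c1ccc(OC)cc1NC(=O)CNCC` is built on a different core; the difference between the two cores is not broken down here. In this assay compound 3 gives 590 nM, the lowest of the three numbers, and its distance to compound 2 and to compound 1 is in each case beyond the scatter.

Compound 4 `C=C(c1cc(OC)c(OC)c(OC)c1)c1ccc(OC)cc1NC(=O)CN(C)C` has not yet been measured. It relates to compound 3 as compound 2 relates to compound 1: the change is dimethylamino in place of ethylamino on a saturated chain carbon bound to a carbonyl carbon, the same change at the same place. If the earlier step carries over, the expected step is a 2.1-fold lower number from compound 3 to compound 4 (0.32 log units; beyond the scatter), resting on the step from compound 1 to compound 2 in this assay and on the value of compound 3, 590 nM. Compound 4 is therefore estimated at 280 nM, expected to fall between 120 nM and 650 nM.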

Compound 4, half-maximal inhibitory concentration: 340 nM
Estimate against measurement, compound 4: 1.2-fold (0.08 log units) below, within the range that was stated.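

In this assay, placing dimethylamino in place of ethylamino on the core of compound 3 gives a 1.7-fold lower number from compound 3 to compound 4 (0.24 log units; within the scatter), so this step alone cannot be told apart from the scatter of repeated measurements. Set beside the step on the core of compound 1, the change gives steps that cannot be distinguished from each other: the same change on two cores in this assay, a 2.3-fold lower number (0.37 log units; beyond the scatter) from compound 1 to compound 2 and a 1.7-fold lower number (0.24 log units; within the scatter) from compound 3 to compound 4, 1.3-fold (0.13 log units) apart, within the scatter of two such steps. This shows that the result on the second core is consistent with the change carrying over between these two cores, but it does not show that the change by itself reliably gives a lower number on the second core, nor does it establish a rule for any other core.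

The compounds shown leave open how the numbers would respond at this place to a primary amine, to diethylamino, or to a longer chain carrying the amine. They also leave open whether the same step would appear on a third core.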